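Phenoxy for Phenyl on an Acetyl Core

A few compounds are considered here, and "the series" means these few. Any claim that something is new, unique, unknown or untested is made for them only; others in the source may bear on it.

Compound 1 `Cc1ccc([S+]([O-])N2CCC[C@H]2COCCCCCC/C=C/c2ccc(-c3ccccc3)cc2)cc1` gives >= 100000 nM in a functional assay on BXPC-3 cells (Homo sapiens) for inhibition, read by XTT assay, with a stated time of 72 h (on this read-out lower numbers stand for stronger inhibition and higher numbers for weaker inhibition), which is a limit of the assay and not a number. Compound 2 `Cc1ccc([S+]([O-])N2CCC[C@H]2COCCCCCC/C=C/c2ccc(Oc3ccccc3)cc2)cc1` gives 50000 nM in this assay. Compound 3 `CC(=O)N1CCC[C@H]1COCCCCCC/C=C/c1ccc(-c2ccccc2)cc1` gives 50000 nM in this assay.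

The change from compound 1 to compound 2 is phenoxy in place of phenyl on an aromatic carbon. The step it made is an at least 2.0-fold lower number from compound 1 to compound 2 (0.30 log units; that floor lies within the scatter), and the value of compound 1 rests on (the limit of >= 100000 nM in this assay, at which 1 of the 3 values shown sits). The two cores differ by a group of 3 heavy atoms (2 carbon, 1 oxygen; no ring) in place of a group of 9 heavy atoms (7 carbon, 1 oxygen, 1 sulfur; one six-membered aromatic ring of carbon only), on an amine nitrogen in a ring, with the step of an at least 2.0-fold lower number from compound 1 to compound 3 (0.30 log units; that floor lies within the scatter). Compound 2 and compound 3 sit level at the digits given, within the usual scatter.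

Compound 4 `CC(=O)N1CCC[C@H]1COCCCCCC/C=C/c1ccc(Oc2ccccc2)cc1` carries the same change on the core of compound 3: phenoxy in place of phenyl on an aromatic carbon. The same change was made from compound 1 to compound 2 and gave only a floor that lies within the scatter, so the step from compound 3 to compound 4 is expected to be a 1.4-fold lower number from compound 3 to compound 4 (0.15 log units; within the scatter), an expectation that rests on an at least 2.0-fold lower number from compound 1 to compound 2 (0.30 log units; that floor lies within the scatter). Compound 4 is estimated at 35000 nM, between 12000 nM and 100000 nM.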

Compound 4, half-maximal inhibitory concentration: 60000 nM
Estimate against measurement, compound 4: 1.7-fold (0.23 log units) below, within the range that was stated.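

On the core of compound 3, phenoxy in place of phenyl on an aromatic carbon gave a 1.2-fold higher number from compound 3 to compound 4 (0.08 log units; within the scatter) in this assay, and exchanging the group on the amine nitrogen in a ring gave a 1.2-fold higher number from compound 2 to compound 4 (0.08 log units; within the scatter). Neither new step shows a real change in this assay, and the phenoxy change cannot be said either to carry over from the core of compound 1 or to fail to do so: the same change on two cores in this assay, an at least 2.0-fold lower number (0.30 log units; that floor lies within the scatter) from compound 1 to compound 2 and a 1.2-fold higher number (0.08 log units; within the scatter) from compound 3 to compound 4; the limit leaves it open whether they differ. The same holds for the exchange on the amine nitrogen, since both earlier steps start from compound 1, whose value is a limit of the assay and not a number: the same change on two cores in this assay, an at least 2.0-fold lower number (0.30 log units; that floor lies within the scatter) from compound 1 to compound 3 and a 1.2-fold higher number (0.08 log units; within the scatter) from compound 2 to compound 4; the limit leaves it open whether they differ.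

The compounds shown leave open whether an amine or a carboxylic acid on the aromatic ring, in place of phenyl or phenoxy, would shift the number beyond the scatter. They also leave open how a shorter or longer chain would behave on either core.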